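The source may hold more compounds than are shown below. What is called first, only, known or untested is meant among the compounds shown, and "the series" means these compounds.

Measured so far in an ADME assay on cells (Hepatocyte, Rattus norvegicus) for pharmacokinetics, read by LC-MS, with a stated time of 90 min, tested at 1 uM (on this read-out higher numbers stand for fast clearance and lower numbers for slow clearance), are three compounds
- compound 1 `CCN(C(=O)OC)c1c(N)nc(-c2nn(Cc3ccccc3F)c3ncccc23)nc1N` gives 11.7 mL/min/kg
- compound 2 `COC(=O)N(Cc1ccccc1F)c1c(N)nc(-c2nn(Cc3ccccc3F)c3ncccc23)nc1N` gives 53.3 mL/min/kg
- compound 3 `COC(=O)N(Cc1cccc(F)c1)c1c(N)nc(-c2nn(Cc3ccccc3F)c3ncccc23)nc1N` gives 53.3 mL/min/kg

Compound 1 has the lowest number of the three, so it is the most slowly cleared of this small set. Compound 4 `CC(C)OC(=O)Nc1c(N)nc(-c2nn(Cc3ccccc3F)c3ncccc23)nc1N` has not yet been measured. It differs from compound 1 by (isopropoxycarbonyl)amino in place of ethyl(methoxycarbonyl)amino on an aromatic carbon, which in words is (isopropoxycarbonyl)amino in place of ethyl(methoxycarbonyl)amino on an aromatic carbon. The two have the same atoms, joined differently.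

Two measured steps alter this same group. With 2-fluorophenyl in place of methyl on the chain there is a 4.6-fold higher number from compound 1 to compound 2 (0.66 log units; beyond the scatter), and with 3-fluorophenyl in that place there is a 4.6-fold higher number from compound 1 to compound 3 (0.66 log units; beyond the scatter). Both are modest but beyond the scatter. Swapping one fluorophenyl for the other gives no change at the digits printed from compound 2 to compound 3 (within the scatter). Neither rise is a close guide, since both add a ring and compound 4 adds none. For the measured compounds named here, they show only that this group can move the number by a modest step, and every change from compound 1 so far has gone upward.

The expected step is small and leans upward, staying within the scatter as a 1.7-fold higher number from compound 1 to compound 4 (0.23 log units; within the scatter). For compound 4 the estimated value is 20 mL/min/kg, with an expected range from 8 mL/min/kg to 50 mL/min/kg.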

Compound 4, clearance: 15 mL/min/kg
Beside the measured number, compound 4's estimate is 1.3-fold (0.12 log units) above it, within the range that was stated.
By their numbers in this assay, from the lowest: compounds 1 and 4 (each within the scatter of the next); then compounds 2 and 3 (each within the scatter of the next).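

Swapping ethyl(methoxycarbonyl)amino for (isopropoxycarbonyl)amino on the aromatic carbon gives a 1.3-fold higher number from compound 1 to compound 4 (0.11 log units; within the scatter) in this assay. For the compounds shown here, every earlier change at this position added a fluorophenyl ring, so this is the first evidence that the group can be rearranged, with the same atoms and a newly added amide hydrogen, without moving the clearance beyond the scatter. No supporting measurement is available to explain this result.

This single step alters two parts of the group at once, removing the ethyl group from the nitrogen and replacing the methyl of the carbamate with isopropyl, so the two contributions cannot be told apart. A compound carrying (methoxycarbonyl)amino, or one keeping the ethyl group on the nitrogen alongside the isopropoxycarbonyl group, would help separate them, while a plain amine at this position would show whether the carbonyl-containing group is needed at all.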